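The compounds below may be only part of what the source reports. "The series", "measured", "known", "first", "only" and "open" are said of these compounds alone.

Measured so far:
Compound 1 `CN(C)/C=N/c1c(C=O)c(-c2ccccc2)nn1-c1ccccc1` gives 23500 nM in a functional assay on Jurkat cells (Homo sapiens) for inhibition, read by MTT assay, with a stated time of 72 h; a lower number here means a stronger inhibitor of growth, a higher number a weaker inhibitor of growth.
Compound 2 `CN(C)/C=N/c1c(C=O)c(-c2ccccc2)nn1-c1cccc(Cl)c1` gives 8300 nM in this assay.
Compound 3 `CN(C)/C=N/c1c(C=O)c(-c2ccccc2)nn1-c1cccc([N+](=O)[O-])c1` reaches only a limit, > 50000 nM, in this assay.

Of the two numbers measured, compound 1 holds the higher one; the step of a 2.8-fold lower number from compound 1 to compound 2 (0.45 log units; beyond the scatter) sets compound 2 apart from it, and the step of an at least 2.1-fold higher number from compound 1 to compound 3 (0.32 log units; beyond the scatter) runs to a limit, as does an at least 6.0-fold higher number from compound 2 to compound 3 (0.77 log units; beyond the scatter) (the limit of > 50000 nM in this assay, at which 1 of the 3 values shown sits). The compound not yet measured, compound 4 `O=Cc1c(-c2ccccc2)nn(-c2ccccc2)c1/N=C/N1CCCCC1`, differs from compound 1 in one place: piperidin-1-yl in place of dimethylamino on a carbon with a double bond to nitrogen. Among the compounds with values here, none of the measured steps touches that carbon; all three change the ring on the other nitrogen of the shared core, so no measured step bears on this change. With nothing to point either way, compound 4 is expected to sit close to compound 1, a step of a 1.2-fold lower number from compound 1 to compound 4 (0.07 log units; within the scatter) in this assay, not beyond the scatter. The estimate for compound 4 is therefore 20000 nM, with a range from 6000 nM to 60000 nM.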

Compound 4, concentration for 50% growth inhibition: 29000 nM
Estimate against measurement, compound 4: 1.5-fold (0.16 log units) below; the measured number falls inside the stated range.
By their numbers in this assay, from the lowest: compound 2; then compounds 1 and 4 (each within the scatter of the next). At a limit, above all of these: compound 3.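

Within the data shown here, until now, every step had changed the ring on the other nitrogen of the shared core, so compound 4 gives the first reading at the carbon with a double bond to nitrogen. Replacing dimethylamino with piperidin-1-yl, which brings in a six-membered non-aromatic ring, gives a 1.2-fold higher number from compound 1 to compound 4 (0.09 log units; within the scatter) in this assay, so the two groups cannot be told apart at this place by this read-out. Nothing at hand bears on why the two groups read alike.

Still open, on these data alone, is whether a morpholine ring or a longer carbon chain at the same carbon would shift the number beyond the scatter. Also open, as far as these compounds go, is whether piperidin-1-yl would read the same on the chloro-bearing ring of compound 2, which gives 8300 nM.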